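Methyl on the Anilino Ring of a Sulfonamide Agonist

A few compounds are considered here, and "the series" means these few. Any claim that something is new, unique, unknown or untested is made for them only; others in the source may bear on it.

Three compounds have so far been measured in a functional assay on HEK293 cells for agonist activity at probable G-protein coupled receptor 27 (Homo sapiens), read by a luciferase reporter and beta-arrestin recruitment, with a stated time of 10 min; on this read-out higher numbers stand for an effect only at larger amounts of compound and lower numbers for an effect already at smaller amounts:

Compound 1 `O=C(Nc1ccc(S(=O)(=O)NCc2ccccc2)cc1)c1ccc(Cl)cc1Cl`: > 100000 nM
Compound 2 `O=C(Nc1ccc(S(=O)(=O)Nc2ccc(Cl)cc2)cc1)c1ccc(Cl)cc1Cl`: > 100000 nM
Compound 3 `O=C(Nc1ccc(S(=O)(=O)Nc2ccccc2)cc1)c1ccc(Cl)cc1Cl`: 457 nM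

The value for compound 1 is a limit of the assay, not a number. The value for compound 2 is likewise a limit (the limit of > 100000 nM in this assay, at which 2 of the 3 values shown sit). Compound 3 therefore gives the only real number shown and is the sole measured point from which to start.

Compound 4 `Cc1ccccc1NS(=O)(=O)c1ccc(NC(=O)c2ccc(Cl)cc2Cl)cc1` differs from compound 3 by methyl in place of hydrogen on an aromatic carbon. Among the measured compounds shown here, two measured steps touch on this change. The step of an at least 210-fold lower number from compound 1 to compound 3 (2.34 log units; beyond the scatter) shows that the group on the sulfonamide nitrogen decides whether any effect is seen at all. The step of an at least 210-fold lower number from compound 2 to compound 3 (2.34 log units; beyond the scatter) shows that a chloro on the anilino ring wipes out the effect. The methyl of compound 4 is a different group at a different place on that same ring, so the outcome of the chloro step cannot simply be carried over, but it warns that substituents on this ring are not tolerated freely.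

A weakening is therefore expected, less severe than an at least 210-fold lower number from compound 2 to compound 3 (2.34 log units; beyond the scatter) yet beyond the scatter: the expected step is a 5.5-fold higher number from compound 3 to compound 4 (0.74 log units; beyond the scatter). Compound 4 is estimated at 2500 nM, with a range from 500 nM to 30000 nM.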

Compound 4, half-maximal effective concentration: 1230 nM
Beside the measured number, compound 4's estimate is 2.0-fold (0.31 log units) above it, within the range that was stated.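

In this assay, a methyl on the anilino ring, ortho to a large group, keeps a measurable effect at a modest cost: a 2.7-fold higher number from compound 3 to compound 4 (0.43 log units; beyond the scatter). Until now the only substituted anilino ring shown was the 4-chlorophenyl of compound 2, so it was unclear whether this ring could carry any substituent at all, and the 2-methylphenyl group shows that it can, with an at least 81-fold lower number from compound 2 to compound 4 (1.91 log units; beyond the scatter) and, against the benzyl group, an at least 81-fold lower number from compound 1 to compound 4 (1.91 log units; beyond the scatter). Both of these last two steps start from a value that is a limit of the assay, not a number: the limit of > 100000 nM in this assay, at which 2 of the 4 values shown sit.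

From the compounds shown here alone, it remains open whether the loss seen in compound 2 follows from the chloro itself or from where it sits on the ring, and a 4-methylphenyl or a 2-chlorophenyl group on the sulfonamide nitrogen would separate the two. Also open, going by these compounds, is how other groups at the place of the methyl would fare, such as an ethyl, a methoxy, an amine or a carboxylic acid.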